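The source may report more compounds than this note shows. Statements on the series, on what has been measured and on what is new or still open speak of the compounds shown alone.

In a functional assay on CNE-2 cells (Homo sapiens) for inhibition, read by MTT assay, with a stated time of 72 h (on this read-out higher numbers stand for weaker inhibition and lower numbers for stronger inhibition), compound 1 `CNC(=O)CCCCCCCn1nc(-c2cnc3[nH]ccc3c2)c2c(N)ncnc21` gives 8990 nM. Among the measured compounds shown here, that is the higher of the two true numbers so far, the other being 2270 nM for compound 2 `Nc1ncnc2c1c(-c1cnc3[nH]ccc3c1)nn2CCCCCCCCC(=O)NO`. Compound 3 `Nc1nc2cc(-c3nn(CCCC(=O)NO)c4ncnc(N)c34)ccc2o1` reads > 50000 nM in this assay, and this is a limit of the assay, not a number.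

The step now followed leads to compound 4 `Nc1ncnc2c1c(-c1cnc3[nH]ccc3c1)nn2CCCCC(=O)NO`, and the change is hydroxycarbamoyl in place of 3-(methylcarbamoyl)propyl on a saturated chain carbon, four bonds along the chain from an aromatic nitrogen. In words, hydroxycarbamoyl stands in place of 3-(methylcarbamoyl)propyl on a saturated chain carbon, four bonds along the chain from an aromatic nitrogen. Cut one bond further out, the same difference reads 6-(methylcarbamoyl)hexyl to 3-(hydroxycarbamoyl)propyl.

For the measured compounds named here, only one measured step bears on this change, a 4.0-fold lower number from compound 1 to compound 2 (0.60 log units; beyond the scatter), which is modest and also brings in a hydroxycarbamoyl end. Going by the values given here, that step kept a long chain, however, and no measured step isolates a shorter chain on this core. The limit of compound 3 at > 50000 nM warns against simply carrying the gain over, so a modest rise is expected rather than a fall. The expected change is a 2.2-fold higher number from compound 1 to compound 4 (0.35 log units; beyond the scatter), an estimate with wide uncertainty. For compound 4 the estimated value is 20000 nM, with an expected range from 6000 nM to 50000 nM.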

Compound 4, half-maximal inhibitory concentration: > 150000 nM
Compound 4 ended at the assay's limit; the forecaster's own chance of this, stated with the estimate: 30%; at least 7.5-fold (0.87 log units) between middle value and limit.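

In this assay, compound 4 stands at a limit of the assay and not at a number: the limit of > 150000 nM in this assay, at which 1 of the 4 values shown sits.

Among the compounds shown here, with the hydroxycarbamoyl end kept, shortening the chain by replacing 4-(hydroxycarbamoyl)butyl with hydroxycarbamoyl at this saturated chain carbon, four bonds along the chain from an aromatic nitrogen, gives an at least 66-fold higher number from compound 2 to compound 4 (1.82 log units; beyond the scatter), so chain length on the shared core matters greatly, which no earlier step could show. The change from 3-(methylcarbamoyl)propyl to hydroxycarbamoyl gives an at least 16-fold higher number from compound 1 to compound 4 (1.22 log units; beyond the scatter), whereas the long-chain change gave a 4.0-fold lower number from compound 1 to compound 2 (0.60 log units; beyond the scatter), so a hydroxycarbamoyl end does not bring a lower number regardless of chain length.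

The compounds shown leave open how the number changes with chain length, which a chain of intermediate length ending in hydroxycarbamoyl, or a longer chain with the same end, would help to settle. They also leave open whether a short chain ending in methylcarbamoyl or in a carboxylic acid would behave like compound 4, which would separate the contribution of the end group from that of the chain.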